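The source may hold more compounds than are shown below. What is called first, only, known or untested is meant among the compounds shown, and "the series" means these compounds.

In an ADME assay on MCF-10A cells (Homo sapiens) for inhibition, with a stated time of 48 h (a higher number here means a weaker inhibitor, a lower number a stronger inhibitor), compound 1 `O=C(Nc1ccc(C(F)(F)F)cc1)N1CCC[C@H]1c1nc(-c2ccccc2)no1` gives > 50000 nM as a limit, not a number. Compound 2 `N#Cc1ccc(NC(=O)N2CCC[C@H]2c2nc(-c3ccccc3)no2)cc1` stands at > 50000 nM and that too is only a limit. Compound 3 `O=C(Nc1ccc(OC(F)(F)F)cc1)N1CCC[C@H]1c1nc(-c2ccccc2)no1` has trifluoromethoxy in place of cyano on an aromatic carbon, para to a large group, and the count of that change is trifluoromethoxy in place of cyano on an aromatic carbon for the two structures. Going by the values given here, the one measured step at this place is a step that the two limits leave unreadable from compound 1 to compound 2 and offers no size to carry over. With the limit of > 50000 nM in this assay, at which 2 of the 2 values shown sit, for compound 1 and compound 2 alike, no step beyond the scatter is expected for compound 3. The expected change is a number no higher from compound 2 to compound 3 (the limit leaves the size open) and this is only an estimate. Compound 3 is expected at 50000 nM within an estimated range from 20000 nM to 100000 nM.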

Compound 3, half-maximal inhibitory concentration: > 50000 nM
Compound 3: no number, only a limit; the forecaster's own chance of this, stated with the estimate: 85%; the middle value sits exactly at the limit.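

Going by these compounds alone, compound 1, compound 2 and compound 3 all give only a limit, not a number, so no step between them can be read: the limit of > 50000 nM in this assay, at which 3 of the 3 values shown sit. Going by these compounds, how trifluoromethyl, cyano and trifluoromethoxy compare in this assay stays open.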